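The source may hold more compounds than are shown below. What is called first, only, known or untested is meant among the compounds shown, and "the series" means these compounds.

Compound 1, `CNC(=O)c1sc(N2CC3CC2(CNC(=O)c2c[nH]c4ncc(C(F)(F)F)cc24)C3)nc1C(F)(F)F`, is examined in a physicochemical assay for lipophilicity, at pH 7.4 (on this read-out higher numbers stand for higher lipophilicity and lower numbers for lower lipophilicity), alongside compound 2, `CS(=O)(=O)c1cnc(Nc2ccc(O)cc2)nc1NCc1ccccc1`, and compound 3, `CNc1nc(OC2CCCC2)nc2c1ncn2Cc1c(F)cccc1F`. Compound 1 gives 4.2. Compound 3 gives 4.3, a number so close to that of compound 1 that the two cannot be told apart by this measurement. Compound 2 gives 2.8, which lies clearly below the value of compound 1. The next compound, compound 4, `CNC(=O)c1sc(N2CC3CC2(CNC(=O)c2c[nH]c4ncc(C)cc24)C3)nc1C(F)(F)F`, has not yet been measured. It differs from compound 1 in one place: methyl in place of trifluoromethyl on an aromatic carbon. Within the data shown here, no measured pair shows what such a swap does here. Since trifluoromethyl leaves and methyl enters, a downward step from compound 1 to compound 4 of a number 0.70 log units lower from compound 1 to compound 4 (beyond the scatter) is expected, beyond the usual scatter. Compound 4 is thus estimated at 3.5, between 3 and 4.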

Compound 4, distribution coefficient: 3.5
The estimate for compound 4 equals the measured number at the digits printed, and the stated range covers the measured number.
By their numbers in this assay, from the lowest: compound 2; then compound 4; then compounds 1 and 3 (each within the scatter of the next).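

Among these compounds, the swap of trifluoromethyl for methyl on this aromatic carbon gives the first one-place comparison here: in this assay it produces a number 0.70 log units lower from compound 1 to compound 4 (beyond the scatter). The number therefore responds to which of these two groups sits at this position on the shared core. Nothing measured here accounts for the size of this step.

Where a chlorine atom, a nitrile or a methoxy group at this position would fall remains open. With a single pair, it is also unknown whether the same swap elsewhere on the core would give a similar step.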